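The source may hold more compounds than are shown below. What is called first, only, known or untested is meant among the compounds shown, and "the series" means these compounds.

Of the compounds shown here, two have been measured so far. Among the compounds with values here, compound 1 `CCOC(=O)c1cnc(NN2C(=O)CCC2=O)nc1C(F)(F)F` and compound 2 `CCOC(=O)c1cnc(NN2C(=O)C=C(C)C2=O)nc1C` share a core and differ at more than one place, so no single step between them is counted. In a functional assay on Jurkat cells (Homo sapiens) for inhibition (on this read-out lower numbers stand for stronger inhibition and higher numbers for weaker inhibition), compound 1 gives 1600 nM, and in this assay compound 2 gives 1900 nM; compound 2 shows the higher of the two numbers, but the gap to compound 1 lies within the scatter, so the two values tell of no real difference.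

Compound 3 `CCOC(=O)c1cnc(NN2C(=O)C=C(C)C2=O)nc1-c1ccc(Cl)s1` has not yet been measured. It differs from compound 2 in one place, (5-chlorothiophen-2-yl in place of methyl on an aromatic carbon), on an aromatic carbon of a six-membered aromatic ring with 2 nitrogen. Within the data shown here, nothing among the measured compounds shows what this change does, so any expectation rests on the structural change alone. A modest move toward stronger inhibition is expected, and the step of a 2.7-fold lower number from compound 2 to compound 3 (0.43 log units; beyond the scatter) is the size of change that is estimated. For compound 3 in this assay the estimate is 700 nM, expected to fall between 200 nM and 3000 nM.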

Compound 3, half-maximal inhibitory concentration: 520 nM
Compound 3: the middle estimate sits 1.3-fold (0.13 log units) above what was measured, and the stated range covers the measured number.
By their numbers in this assay, from the lowest: compound 3; then compounds 1 and 2 (each within the scatter of the next).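

In this assay the change from methyl to 5-chlorothiophen-2-yl gives a 3.7-fold lower number from compound 2 to compound 3 (0.56 log units; beyond the scatter) and so shows that this aromatic carbon, ortho to an ethoxycarbonyl group, is a place where a single change moves the read-out beyond the scatter, which compounds 1 and 2 could not show because they differ in more than one place. The position also tolerates far more than a lone methyl: a whole five-membered aromatic ring carrying a chlorine enters here, and inhibition grows rather than being lost. No measurement is available that explains this gain, so it cannot yet be assigned to any part of the new group.

Going by these compounds, whether the gain belongs to the chlorine or to the thiophene ring itself stays open, as does how a thiophen-2-yl group without chlorine, a phenyl ring or a simple amine would behave on this carbon. Also open, on these data alone, is whether 5-chlorothiophen-2-yl would give a similar gain on the core of compound 1, where the saturated imide ring carries no methyl.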